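The compounds below may be only part of what the source reports. "The series", "measured", "known", "first", "only" and "open" are said of these compounds alone.

Three compounds have a reading in an assay on HEK293 cells for inhibition of kynurenine 3-monooxygenase (Homo sapiens), read by LC-MS, with a stated time of 20 h; on this read-out higher numbers stand for weaker inhibition and lower numbers for stronger inhibition. Compound 1 `C[C@@H](Oc1cc2onc(CCC(=O)O)c2cc1Cl)c1ccc(F)cn1` gives 31.6 nM. Compound 3 `Cc1ccc([C@@H](C)Oc2cc3onc(CCC(=O)O)c3cc2Cl)nn1` gives 3.16 nM. Compound 2 `O=C(O)CCn1c(=O)oc2cc(OCc3ccccn3)c(Cl)cc21`, which carries a different core from the other two, gives 5010 nM, the highest of the three numbers; the gap to compound 1 and the larger gap to compound 3 are both beyond the scatter.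

The unmeasured compound 4 `O=C(O)CCn1c(=O)oc2cc(OCC3CCC3)c(Cl)cc21` keeps the core of compound 2 and differs from it in one place: cyclobutyl in place of pyridin-2-yl on a saturated chain carbon bound to an oxygen on an aromatic ring.

Going by the values given here, the only measured step, a 10-fold lower number from compound 1 to compound 3 (1.00 log units; beyond the scatter), concerns a swap of one six-membered aromatic group for another on the core of compounds 1 and 3, so it does not show what replacing an aromatic ring by a saturated one does on the core of compound 2. Among the compounds with values here, no measured pair tests the change from compound 2 to compound 4 directly. With nothing pointing either way, the expected step of a 1.2-fold higher number from compound 2 to compound 4 (0.08 log units; within the scatter) is none beyond the scatter. Compound 4 is therefore estimated at 6000 nM, in a range from 1500 nM to 25000 nM, with the wide spread reflecting the absence of a comparable measured step.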

Compound 4, half-maximal inhibitory concentration: 1260 nM
Beside the measured number, compound 4's estimate is 4.8-fold (0.68 log units) above it; the measured number lies below the stated range.
By their numbers in this assay, from the lowest: compound 3; then compound 1; then compound 4; then compound 2.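

In this assay, cyclobutyl in place of pyridin-2-yl on a saturated chain carbon bound to an oxygen on an aromatic ring gives a 4.0-fold lower number from compound 2 to compound 4 (0.60 log units; beyond the scatter). On the core of compound 2, this place therefore does not depend on a six-membered aromatic ring with a hetero atom, since a four-membered non-aromatic ring of carbon only gives the lower number, whereas the earlier step had only exchanged one aromatic group for another on a different core. Nothing at hand explains the size of this step.

The compounds shown do not separate the loss of the ring nitrogen from the loss of aromaticity or the change in ring size, as neither a phenyl nor a cyclohexyl group appears at this place. They also leave open whether cyclobutyl would bring a similar step on the core of compound 1 and compound 3.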